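Notes: heptyl in place of 4-chlorophenyl

The source may report more compounds than this note shows. Statements on the series, on what has been measured and on what is new or still open speak of the compounds shown alone.

For the measured compounds named here, in a functional assay on A549 cells (Homo sapiens) for inhibition, read by MTT assay, with a stated time of 48 h (a lower number here means a stronger inhibitor, a higher number a weaker inhibitor), compound 1 `Brc1ccc2[nH]cc(C(c3c[nH]c4ccc(Br)cc34)C3CCCCC3)c2c1` gives 5500 nM and compound 2 `Clc1ccc(C(c2c[nH]c3ccc(Br)cc23)c2c[nH]c3ccc(Br)cc23)cc1` gives 8500 nM, so compound 2 stands within the scatter of its only neighbour. Compound 3 `CCCCCCCC(c1c[nH]c2ccc(Br)cc12)c1c[nH]c2ccc(Br)cc12` carries heptyl in place of 4-chlorophenyl on a saturated chain carbon bound to two aromatic carbons. Going by the values given here, the one measured step bearing on this, cyclohexyl to 4-chlorophenyl at that carbon, is a 1.5-fold higher number from compound 1 to compound 2 (0.19 log units; within the scatter). No open chain has been measured yet, so the range stays wide. The expected change, none beyond the scatter, is a 1.2-fold lower number from compound 2 to compound 3 (0.08 log units; within the scatter). Compound 3 is estimated at 7000 nM, with a range of 2800 nM to 18000 nM.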

Compound 3, half-maximal inhibitory concentration: 3500 nM
Estimate against measurement, compound 3: 2.0-fold (0.30 log units) above; the range from low to high includes it.
By their numbers in this assay, from the lowest: compounds 3, 1 and 2 (each within the scatter of the next, the first and the last beyond it).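

In this assay an open chain at the saturated chain carbon bound to two aromatic carbons gives numbers in the same range as the ring-bearing compounds. Heptyl in place of 4-chlorophenyl gives a 2.4-fold lower number from compound 2 to compound 3 (0.39 log units; beyond the scatter) and is the only step shown that lies beyond the scatter, whereas heptyl in place of cyclohexyl gives a 1.6-fold lower number from compound 1 to compound 3 (0.20 log units; within the scatter) and so does not separate from the saturated ring. No measurement on hand accounts for either step. On these data alone, whether a longer chain or a shorter one such as butyl would go further at this carbon stays open, as does the effect of an amine there.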